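The source may hold more compounds than are shown below. What is called first, only, known or untested is meant among the compounds shown, and "the series" means these compounds.

Compound 1 `CC(C)c1onc(-c2c(Cl)cccc2Cl)c1COc1ccc(-c2nc3ccc(C(=O)O)cc3n2C(C)C)cc1`: 3550 nM
Compound 2 `CCC(CC)n1c(-c2ccc(OCc3c(-c4c(Cl)cccc4Cl)noc3C(C)C)cc2Cl)nc2ccc(C(=O)O)cc21`: 1010 nM

In an assay on HEK-293T cells for antagonist activity at vitamin D3 receptor (Homo sapiens), read by a luciferase reporter, with a stated time of 24 h (a higher number here means a weaker inhibitor, a lower number a stronger inhibitor), compound 1 gives 3550 nM, the higher of the two numbers recorded. Compound 2 gives 1010 nM, and the gap between the two lies beyond the usual scatter, so compound 2 is the stronger inhibitor of this pair; the two differ in more than one place, and nothing more can be drawn from them. Compound 3 `CC(=O)C1CCC(Cn2c(-c3ccc(OCc4c(-c5c(Cl)cccc5Cl)noc4C(C)C)cc3)nc3ccc(C(=O)O)cc32)CC1` is not yet measured. It differs from compound 1 by (4-acetylcyclohexyl)methyl in place of isopropyl on an aromatic nitrogen. Among the compounds with values here, no single-change step between measured compounds guides this change. A modest lowering of the number is expected, a 1.8-fold lower number from compound 1 to compound 3 (0.25 log units; within the scatter), close to the edge of the scatter. Compound 3 is estimated at 2000 nM, within 500 nM to 8000 nM.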

Compound 3, half-maximal inhibitory concentration: > 10000 nM
Compound 3: only a limit was reported; the forecaster's own chance of this, stated with the estimate: 10%; middle value at least 5.0-fold (0.69 log units) away from the limit.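

Within the data shown here, this is the first single-change reading at this position. On the aromatic nitrogen, (4-acetylcyclohexyl)methyl in place of isopropyl gives, in this assay, an at least 2.8-fold higher number from compound 1 to compound 3 (0.44 log units; beyond the scatter), so the change weakens inhibition rather than improving it. Compound 3 gives only a limit of the assay, so the full size of the step stays unknown: the limit of > 10000 nM in this assay, at which 1 of the 3 values shown sits.

The compounds shown leave open whether this loss follows the cyclohexane ring or the acetyl group. A plain cyclohexylmethyl on this nitrogen, or an amine or a hydroxyl in place of the acetyl, could separate the two.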